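Chloro for Fluoro at the Edge of this Assay

A few compounds are considered here, and "the series" means these few. Any claim that something is new, unique, unknown or untested is made for them only; others in the source may bear on it.

Compound 1 `CCCCNc1cccc(NC(=O)c2ccc(OCCC)cc2)n1` gives 77800 nM in an in vitro assay on HEK-tsA201 cells for antagonist activity at Neuronal acetylcholine receptor; alpha3/beta4 (Homo sapiens), read by fluorescence and calcium flux; on this read-out higher numbers stand for weaker inhibition and lower numbers for stronger inhibition. Compound 2 `CCCOc1ccc(C(=O)Nc2cccc(Nc3ccccc3F)n2)cc1` reaches only the limit of this assay, > 100000 nM. Compound 3 `CCCOc1ccc(C(=O)Nc2cccc(Nc3ccc(F)cc3)n2)cc1` likewise gives only a limit in this assay, > 100000 nM. Replacing the butyl on the ring nitrogen by a fluorinated phenyl gave an at least 1.2-fold higher number from compound 1 to compound 2 (0.10 log units; that floor lies within the scatter) and an at least 1.2-fold higher number from compound 1 to compound 3 (0.10 log units; that floor lies within the scatter), while moving the fluorine from one phenyl position to the other gave a step that the two limits leave unreadable from compound 2 to compound 3. Two of the three values sit at the limit of > 100000 nM in this assay, at which 2 of the 3 values shown sit, so compound 3 stands at that limit and no number is known for it.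

Compound 4 `CCCOc1ccc(C(=O)Nc2cccc(Nc3ccc(Cl)cc3)n2)cc1` differs from compound 3 by chloro in place of fluoro on an aromatic carbon. Among the compounds with values here, no measured step swaps one halogen for another; the only step touching this phenyl, a step that the two limits leave unreadable from compound 2 to compound 3, is unreadable between two limits. The expected step that the limit leaves unreadable from compound 3 to compound 4 is therefore none beyond the scatter. Compound 4 is expected to give 150000 nM in this assay, in the range 50000 nM to 400000 nM, most likely again as a limit.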

Compound 4, half-maximal inhibitory concentration: > 100000 nM
Compound 4 was reported as a limit; the forecaster's own chance of this, stated with the estimate: 70%; the middle value is on the limit's open side.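

In this assay compound 4 also gives only a limit, so the halogen swap on the 4-fluorophenyl yields no size, and the steps among compound 2, compound 3 and compound 4 cannot be read. What the result adds is that a chlorine on this phenyl, like a fluorine at either phenyl position shown, leaves the value at the limit, and against the butyl of compound 1 the 4-chlorophenyl gives an at least 1.2-fold higher number from compound 1 to compound 4 (0.10 log units; that floor lies within the scatter). Within the data shown here, compound 1 thus remains the only compound here with a number, and the rest stand together: the limit of > 100000 nM in this assay, at which 3 of the 4 values shown sit.

Going by these compounds, whether any group on this phenyl can bring a value within range stays open, for instance a methoxy or a nitrile in place of the chloro. Also open, on these data alone, is how a longer chain or a cyclohexyl in place of the butyl would read in this assay.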